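The compounds below may be only part of what the source reports. "The series", "measured", "known", "first", "only" and "open" are said of these compounds alone.

The series shares one core, seen in compound 1 `CC(C)=CCC/C(C)=C/CC1Cc2c(OCC=C(C)C)cc(=O)n(CCCO)c2CC1(C)C`, which in a functional assay on PANC-1 cells (Homo sapiens) for inhibition, read by MTT assay, with a stated time of 24 h, tested at 10 uM (a lower number here means less inhibition, a higher number more inhibition at the concentration tested (going by the name of the read-out)), gives 30.3%. Among the measured compounds shown here, compound 2 `CC(C)=CCC/C(C)=C/COc1cc(=O)n(CCCO)c2c1CC(C/C=C(\C)CCC=C(C)C)C(C)(C)C2` gives 15.8% in this assay, and the single step recorded, a number 14.5 percentage points lower from compound 1 to compound 2 (beyond the scatter), changes a position far from the chain that is varied below. For the measured compounds named here, compound 3 `CC(C)=CCC/C(C)=C/CC1Cc2c(OCCCNS(=O)(=O)c3ccc(Br)cc3)cc(=O)n(CCCO)c2CC1(C)C` gives 15.2% in this assay, the lowest of the three numbers, within the scatter of compound 2 and beyond the scatter below compound 1; compound 1 and compound 3 differ in the chain on the aromatic oxygen, but no step between them is recorded, so only their two values can be compared.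

Compound 4 `CC(C)=CCC/C(C)=C/CC1Cc2c(OCCCOc3ccc(Cl)cc3)cc(=O)n(CCCO)c2CC1(C)C` has not been measured. It differs from compound 3 as follows: 4-chlorophenoxy in place of ((4-bromophenyl)sulfonyl)amino on a saturated chain carbon, three bonds along the chain from an oxygen on an aromatic ring. Going by the values given here, no measured step touches this chain, so nothing recorded bears directly on the change. Compound 4 is therefore expected to stay near compound 3, with a number 3.8 percentage points higher from compound 3 to compound 4 (within the scatter) not reaching beyond the scatter. The estimate for compound 4 in this assay is 19%, with a range from 4% to 38%.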

Compound 4, a percentage reported as inhibition, at one concentration (the size of the read-out at that concentration, not a potency): 25.2%
The estimate for compound 4 lay 6.2 percentage points below the measured number; measured number inside the range.
By their numbers in this assay, from the lowest: compounds 3, 2, 4 and 1 (each within the scatter of the next, the first and the last beyond it).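

The chain on the aromatic oxygen now has recorded steps, and in this assay none of them leaves the scatter: the first is a number 10 percentage points higher from compound 3 to compound 4 (within the scatter) with 4-chlorophenoxy in place of ((4-bromophenyl)sulfonyl)amino, the second is a number 9.4 percentage points higher from compound 2 to compound 4 (within the scatter) with 2-(4-chlorophenoxy)ethyl in place of 2,6-dimethylhepta-1,5-dien-1-yl, and the third is a number 5.1 percentage points lower from compound 1 to compound 4 (within the scatter) with 2-(4-chlorophenoxy)ethyl in place of 2-methylprop-1-en-1-yl. Compound 4 therefore cannot be told apart from compound 1 or compound 3, although the printed values of those two alone lie beyond the scatter of each other.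

On these data alone, whether an amine or a carboxylic acid at the end of this chain, or a longer chain, would give a step beyond the scatter stays open. The link and the halogen change together from compound 3 to compound 4, so their separate contributions also stay open, and nothing measured here accounts for these numbers.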